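Compound 3 to compound 4: phenyl in place of methyl

The source may hold more compounds than are shown below. What is called first, only, known or untested is meant among the compounds shown, and "the series" means these compounds.

Measured so far in an ADME assay on HepG2 cells (Homo sapiens) for cytotoxicity, read by luminescence, with a stated time of 72 h (on this read-out higher numbers stand for an effect only at larger amounts of compound and lower numbers for an effect already at smaller amounts), are three compounds.
Compound 1 `CCOC(=O)c1c(-c2cccc(Oc3ccccc3)c2)[nH]c2cc(OC)c(OC)cc2c1=O` gives > 21500 nM as a limit.
Compound 2 `CCOC(=O)c1c(-c2cccc(-c3ccccc3)c2)[nH]c2cc(Cl)c(OC)cc2c1=O` gives > 21500 nM as a limit.
Compound 3 `CCOC(=O)c1c(-c2cccc(OC)c2)[nH]c2cc(Cl)c(OC)cc2c1=O` gives > 21500 nM as a limit.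

Compound 3 thus has no exact number and stands with the other two, which also show only a limit. Compound 4 `CCOC(=O)c1c(-c2cccc(Oc3ccccc3)c2)[nH]c2cc(Cl)c(OC)cc2c1=O` has phenyl in place of methyl on an oxygen on an aromatic ring and remains unmeasured. Going by the values given here, the only measured step that bears on this change is a step that the two limits leave unreadable from compound 2 to compound 3 and it shows no size. Because of the limit of > 21500 nM in this assay, at which 3 of the 3 values shown sit, no step beyond the scatter is expected for compound 4 in this assay and no direction can be named. The expected step is a step that the limit leaves unreadable from compound 3 to compound 4 and it remains a rough estimate. For compound 4 the estimate is 25000 nM with a range from 12000 nM to 50000 nM and a report as a limit is the likeliest outcome.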

Compound 4, half-maximal effective concentration: > 21500 nM
Compound 4 gave a limit, no number (the forecaster's own chance of this, stated with the estimate: 85%); the middle value lies beyond the limit too.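

In this assay the steps to compound 4 from compound 1, compound 2 and compound 3 cannot be read, because all four compounds share one limit: the limit of > 21500 nM in this assay, at which 4 of the 4 values shown sit. The compounds shown leave open whether any of these changes alters the half-maximal effective concentration at all.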